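The source may hold more compounds than are shown below. What is called first, only, known or untested is meant among the compounds shown, and "the series" means these compounds.

In a functional assay on NCI-H322M cells (Homo sapiens) for inhibition, read by sulforhodamine B assay, with a stated time of 48 h, tested at 10 uM (on this read-out lower numbers stand for a stronger effect and higher numbers for a weaker effect at the one concentration tested), compound 3 `COc1cc(Cl)cc(-c2nn(-c3cccc(NC(=O)Nc4ccc(Cl)c(Cl)c4)c3)cc2-c2ccncc2)c1` gives 32.3%, which stands second highest among the three measured numbers. Compound 2 `COc1cc(Cl)cc(-c2nn(-c3cccc(NC(=O)Nc4ccc(Cl)c(C(F)(F)F)c4)c3)cc2-c2ccncc2)c1` gives 18.7%, and compound 1 `COc1cc(Cl)cc(-c2nn(-c3cccc(NC(=O)c4ccc(Cl)c(Cl)c4)c3)cc2-c2ccncc2)c1` gives 84.6%. Compound 4 `COc1cc(Cl)cc(-c2nn(-c3cccc(NC(=O)c4cccc(C(F)(F)F)c4)c3)cc2-c2ccncc2)c1` has not yet been measured. It differs from compound 3 in one place: 3-(trifluoromethyl)phenyl in place of (3,4-dichlorophenyl)amino on a carbonyl carbon. The step that bears most on it runs from compound 1 to compound 3, where a number 52.3 percentage points lower from compound 1 to compound 3 (beyond the scatter); compound 4 carries the same kind of group at the carbonyl carbon as compound 1, though with a different ring. The other step, a number 65.9 percentage points lower from compound 1 to compound 2 (beyond the scatter), points the same way. The expected step is therefore a number 42.7 percentage points higher from compound 3 to compound 4 (beyond the scatter), a large rise. Compound 4 is estimated at 75%, with a range from 50% to 95%.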

Compound 4, a percentage reported as activity, at one concentration (the size of the read-out at that concentration, not a potency): 78.6%
The estimate for compound 4 lay 3.6 percentage points below the measured number, and the stated range covers the measured number.
By their numbers in this assay, from the lowest: compound 2; then compound 3; then compounds 4 and 1 (each within the scatter of the next).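

In this assay, replacing (3,4-dichlorophenyl)amino with 3-(trifluoromethyl)phenyl on the carbonyl carbon gives a number 46.3 percentage points higher from compound 3 to compound 4 (beyond the scatter), and the same replacement of (4-chloro-3-(trifluoromethyl)phenyl)amino gives a number 59.9 percentage points higher from compound 2 to compound 4 (beyond the scatter). With the ring attached directly to the carbonyl carbon, exchanging 3,4-dichlorophenyl for 3-(trifluoromethyl)phenyl gives only a number 6 percentage points lower from compound 1 to compound 4 (within the scatter), so in these four compounds the amino link separates the numbers more than the ring substitution does. Nothing available here explains this difference. Going by these compounds, it remains open how a (3-(trifluoromethyl)phenyl)amino group would read at this position, and whether an oxygen or methylene link to the same ring would behave like the amino link.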